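A few compounds are considered here, and "the series" means these few. Any claim that something is new, unique, unknown or untested is made for them only; others in the source may bear on it.

Measured so far:
compound 1 `O=C(COc1ccc(CN2CC=C(c3c[nH]c4cccc(F)c34)CC2)c(F)c1)NO`: 5560 nM
compound 2 `Cc1ccc2[nH]cc(C3=CCN(Cc4ccc(OCC(=O)NO)cc4F)CC3)c2c1`: 1950 nM

Both compounds were tested in a functional assay on SW480 cells (Homo sapiens) for antiproliferative activity, with a stated time of 72 h; on this read-out higher numbers stand for weaker inhibition and lower numbers for stronger inhibition. Of the two, compound 2 has the lower number, 1950 nM, and so the stronger inhibition, with a gap to compound 1 that lies beyond the scatter.

The unmeasured compound 3 `Cc1[nH]c2ccccc2c1C1=CCN(Cc2ccc(OCC(=O)NO)cc2F)CC1` differs from compound 2 in one group: 2-methyl-1H-indol-3-yl in place of 5-methyl-1H-indol-3-yl on a double-bonded ring carbon. The two have the same atoms, joined differently, as 2-methyl-1H-indol-3-yl takes the place of 5-methyl-1H-indol-3-yl.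

Among the measured compounds shown here, only one measured step bears on this change: a 2.9-fold lower number from compound 1 to compound 2 (0.46 log units; beyond the scatter). It was modest and was made at the same place on the molecule, so changes there can shift the number. However, no measured compound carries the 2-methyl-1H-indol-3-yl group, and the data give no direction for this swap. The best expectation in this assay is therefore no step beyond the scatter, though a modest step either way remains possible.

The expected change is a 1.2-fold higher number from compound 2 to compound 3 (0.09 log units; within the scatter). Compound 3 is estimated at 2400 nM, with an expected range of 800 nM to 7000 nM.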

Compound 3, half-maximal inhibitory concentration: 1600 nM
The estimate for compound 3 lay 1.5-fold (0.18 log units) above the measured number; measured number inside the range.
By their numbers in this assay, from the lowest: compounds 3 and 2 (each within the scatter of the next); then compound 1.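

Moving the methyl group within the group on the double-bonded ring carbon makes no clear difference in this assay: the swap to 2-methyl-1H-indol-3-yl gives a 1.2-fold lower number from compound 2 to compound 3 (0.09 log units; within the scatter). The same group set against the 4-fluoro-1H-indol-3-yl of compound 1 gives a 3.5-fold lower number from compound 1 to compound 3 (0.54 log units; beyond the scatter), so this second methyl-bearing compound also stands apart from the fluorine-bearing one, and among these three compounds none goes against that split. Nothing at hand explains why these two methyl placements read alike, as no supporting measurement accompanies these numbers.

The compounds shown leave open what the plain 1H-indol-3-yl group, with neither methyl nor fluoro on it, would give, so it stays unclear whether the methyl groups lower the number or the 4-fluoro group raises it. They also leave open whether the tolerance seen for the two methyl placements would hold for a methoxy group, a carboxylic acid or an amine at those same places.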